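The compounds below may be only part of what the source reports. "The series", "measured", "known", "first", "only" and "open" are said of these compounds alone.

Measured so far:
compound 1, `CCCc1nc(-c2ccccc2)c(CNCCN2CCN(c3ccccc3Cl)CC2)o1`: 4370 nM
compound 2, `CCCc1nc(-c2ccccc2)c(CNCCCN2CCN(c3ccc(Cl)cc3)CC2)o1`: 1310 nM
compound 3, `CCCc1nc(-c2ccccc2)c(CNCCCN2CCN(c3cccc(F)c3)CC2)o1`: 3030 nM

In an assay on HEK293 cells for inhibition of Voltage-dependent T-type calcium channel subunit alpha-1G (Homo sapiens), read by patch clamp (a higher number here means a weaker inhibitor, a lower number a stronger inhibitor), compound 1 gives the highest of the three numbers; compound 3 stands within the scatter of it, while compound 2 sits beyond the scatter at a lower number. Compound 4 `CCCc1nc(-c2ccccc2)c(CNCCN2CCN(c3ccc(F)cc3)CC2)o1` differs from compound 1 by 4-fluorophenyl in place of 2-chlorophenyl on an amine nitrogen in a ring. Among the compounds with values here, only one measured step concerns the aryl group on the ring nitrogen: a 2.3-fold higher number from compound 2 to compound 3 (0.36 log units; beyond the scatter), a modest change. Within the data shown here, no measured pair swaps the same two groups, and compounds 2 and 3 differ from compound 1 in more than one place, so the bearing is loose. Compound 4 is therefore expected to move by a 1.5-fold lower number from compound 1 to compound 4 (0.16 log units; within the scatter), a small step toward a lower number at most. The estimate for compound 4 is 3000 nM, with a range from 1200 nM to 8000 nM.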

Compound 4, half-maximal inhibitory concentration: 7080 nM
For compound 4 the middle estimate is 2.4-fold (0.37 log units) below the measured one; the range from low to high includes it.
By their numbers in this assay, from the lowest: compound 2; then compounds 3, 1 and 4 (each within the scatter of the next, the first and the last beyond it).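

In this assay, putting 4-fluorophenyl in place of 2-chlorophenyl on the ring amine nitrogen gives a 1.6-fold higher number from compound 1 to compound 4 (0.21 log units; within the scatter), so this swap does not separate the two aryl groups on the chain of compound 1. The earlier aryl change, a 2.3-fold higher number from compound 2 to compound 3 (0.36 log units; beyond the scatter), lay beyond the scatter, but it involved other groups on a different chain. No supporting evidence is available to explain this result. As far as these compounds go, the swap changes both halogen and ring position, so their separate contributions remain open. From the compounds shown here alone, it also remains open whether a methoxy group or a second chlorine at this aryl group would shift the value.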